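Dropping a Chloro Group: From Compound 2 to Compound 3

The source may hold more compounds than are shown below. What is called first, only, known or untested is meant among the compounds shown, and "the series" means these compounds.

Compound 1 `O=C(Nc1cccc(-n2cc(-c3ccncc3)c(-c3cc(O)cc(Cl)c3)n2)c1)Nc1ccc(Cl)c(C(F)(F)F)c1`: 93%
Compound 2 `COc1cc(Cl)cc(-c2nn(-c3cccc(NC(=O)Nc4ccc(Cl)c(C(F)(F)F)c4)c3)cc2-c2ccncc2)c1`: 57%

Both were measured in a functional assay on ACHN cells (Homo sapiens) for inhibition, read by sulforhodamine B assay, with a stated time of 48 h, tested at 0.1 uM; on this read-out lower numbers stand for a stronger effect and higher numbers for a weaker effect at the one concentration tested. Within the data shown here, compound 2 stands lowest of the two numbers, and so shows the stronger effect; the gap to compound 1 is the single measured step, a number 36 percentage points lower from compound 1 to compound 2 (beyond the scatter), which arose from a methyl in place of hydrogen on an oxygen on an aromatic ring.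

Compound 3 `COc1cc(Cl)cc(-c2nn(-c3cccc(NC(=O)Nc4cccc(C(F)(F)F)c4)c3)cc2-c2ccncc2)c1` is the next compound. It differs from compound 2 by hydrogen in place of chloro on an aromatic carbon. Among the measured compounds shown here, the one measured step sits on a different part of the molecule and so bears on this change only indirectly; no step with a chloro leaving is available. The expectation is therefore a modest move in this assay, with a wide range covering both directions.

Compound 3 is estimated at 68%, between 45% and 90%, which means an expected step of a number 11 percentage points higher from compound 2 to compound 3 (beyond the scatter).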

Compound 3, a percentage reported as activity, at one concentration (the size of the read-out at that concentration, not a potency): 92%
Estimate against measurement, compound 3: 24 percentage points below, outside the stated range (above it).
By their numbers in this assay, from the lowest: compound 2; then compounds 3 and 1 (each within the scatter of the next).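

In this assay, removing one chloro from the 4-chloro-3-(trifluoromethyl)phenyl group gives a number 35 percentage points higher from compound 2 to compound 3 (beyond the scatter), so the stronger effect of compound 2 depends on this single atom at this carbon. The earlier step concerned only the methyl on the oxygen at the other aryl group, so this result shows that a second, separate part of the molecule also strongly affects the read-out at the one concentration tested. No measurement here explains why the chloro matters.

Going by these compounds, it remains open whether fluoro, bromo or a nitrile on the same carbon, ortho to the trifluoromethyl group, would match chloro or hydrogen. On these data alone, it is also open whether losing the chloro would have a similar effect with a hydroxyl in place of the methoxy group.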